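Trimming the Amide Chain on an Adenosine Receptor Ligand

The source may hold more compounds than are shown below. What is called first, only, known or untested is meant among the compounds shown, and "the series" means these compounds.

Three measured compounds share one core. Compound 1 `CCNC(=O)[C@H]1OC(n2cnc3c(NC4CCCCC4)ncnc32)[C@H](O)[C@@H]1O` gives 1.7 nM in an assay with adenosine receptor A1 (Rattus norvegicus) as the target; a higher number here means a weaker inhibitor, a lower number a stronger inhibitor. Compound 2 `CCNC(=O)[C@H]1OC(n2cnc3c(NC(CC)CC)ncnc32)[C@H](O)[C@@H]1O` gives 1.5 nM, and compound 3 `CCNC(=O)[C@H]1OC(n2cnc3c(Nc4ccc(OC)cc4)ncnc32)[C@H](O)[C@@H]1O` gives 4.6 nM. Compound 2 holds the lowest of the three numbers, though a 1.1-fold lower number from compound 1 to compound 2 (0.05 log units; within the scatter) lies within the scatter, whereas a 3.1-fold higher number from compound 2 to compound 3 (0.49 log units; beyond the scatter) and a 2.7-fold higher number from compound 1 to compound 3 (0.43 log units; beyond the scatter) go beyond it. Compound 4 `CCC(CC)Nc1ncnc2c1ncn2C1O[C@H](C(=O)NC)[C@@H](O)[C@H]1O` differs from compound 2 by hydrogen in place of methyl on a saturated chain carbon bound to an amide-type nitrogen. Among the compounds with values here, all three measured steps alter the group on the aromatic nitrogen; none touches the amide chain, so no measured step bears directly on this change. Removing one carbon from that chain is expected to give a step of a 1.3-fold higher number from compound 2 to compound 4 (0.12 log units; within the scatter), no larger than the scatter. Compound 4 is therefore expected to give about 2 nM, within 0.9 nM to 5 nM.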

Compound 4, half-maximal inhibitory concentration: 20 nM
For compound 4 the middle estimate is 10-fold (1.00 log units) below the measured one, and the stated range ends below it.
By their numbers in this assay, from the lowest: compounds 2 and 1 (each within the scatter of the next); then compound 3; then compound 4.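

In this assay, within the data shown here, the change from ethylcarbamoyl to methylcarbamoyl gives a 13-fold higher number from compound 2 to compound 4 (1.12 log units; beyond the scatter) and outweighs every step the earlier compounds show on the aromatic nitrogen. The amide chain, which those compounds left unchanged, therefore responds strongly here to the loss of a methyl, a change of just 1 heavy atom. No measurement at hand explains this step.

On these data alone, whether a propyl or cyclopropyl group on the amide nitrogen would keep the number of compound 2 remains open. So does whether the same change carries the same weight with cyclohexyl or 4-methoxyphenyl on the aromatic nitrogen.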